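The source may hold more compounds than are shown below. What is called first, only, known or untested is meant among the compounds shown, and "the series" means these compounds.

Working notes on a small series sharing one core, read in a functional assay on the whole organism for antagonist activity, with Rattus norvegicus as the target; on this read-out higher numbers stand for an effect only at larger amounts of compound and lower numbers for an effect already at smaller amounts. Within the data shown here, compound 2 `Cc1c(Cl)c(Cl)[n+]([O-])c2nc(O)c(O)nc12` gives 30 mg/kg, the middle of the three numbers available so far. Compound 1 `Cc1c(Cl)cnc2nc(O)c(O)nc12` at 20 mg/kg and compound 3 `[O-][n+]1c(Cl)c(C(F)(F)F)cc2nc(O)c(O)nc21` at 60 mg/kg each lie within the usual scatter of compound 2, so the series offers no clear separation around it.

Compound 4 `Cc1c(Cl)c[n+]([O-])c2nc(O)c(O)nc12` has not yet been measured. It derives from compound 2 through one change, hydrogen in place of chloro on an aromatic carbon. Among the measured compounds shown here, no two measured compounds differ in one place only, so the series holds no direct precedent for the size of this step. From the compounds shown here alone, without such a precedent, no step beyond the scatter is expected in this assay, and the direction remains open. The expectation starts from compound 2 at 30 mg/kg, with both other measured compounds within the scatter of that number. The expected change, a 1.2-fold lower number from compound 2 to compound 4 (0.08 log units; within the scatter), is estimated to remain within the usual scatter. For compound 4 the estimated value is 25 mg/kg, with an expected range of 10 mg/kg to 60 mg/kg.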

Compound 4, dose for half-maximal effect: 7 mg/kg
Compound 4: the middle estimate sits 3.6-fold (0.55 log units) above what was measured; the whole stated range lies above it.
By their numbers in this assay, from the lowest: compound 4; then compounds 1, 2 and 3 (each within the scatter of the next, the first and the last beyond it).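

The pair gives the series its first step in one place only. In this assay there is a 4.3-fold lower number from compound 2 to compound 4 (0.63 log units; beyond the scatter), and this step lies beyond the scatter, whereas compounds 1, 2 and 3 offered no such single change to read. At this aromatic carbon, next to the ring nitrogen and ortho to a chloro group, the chloro substituent is therefore not required for the effect on this whole-organism read-out, and with hydrogen in its place the effect already appears at a smaller dose.

From the compounds shown here alone, it remains open whether this position merely tolerates hydrogen or responds to the size and kind of its substituent, since fluoro, a methoxy group, an amine or a carboxylic acid at the same carbon would each test that in a different way, and one pair cannot say whether the step would recur on another member of the series. Nothing available here bears on what lies behind the size of this step, so the result stands as an observation on one pair of compounds.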